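This account rests on a few compounds, and the source may have more. Where it says the series, first, only, none or still open, it means among the compounds named here.

Measured so far:
- compound 1, `CCn1c(CNc2ccccc2)nnc1SCC(=O)Nc1ccc(C(=O)OC)cc1`: "not determined" (no result reported)
- compound 2, `CCn1c(CNc2ccccc2)nnc1SCC(=O)Nc1ccc(C(=O)NC)cc1`: > 10000 nM

Both compounds share one core and differ only in the group on the far benzene ring. For compound 1 no result was reported in an assay on isolated protein for inhibition of long-chain fatty acid transport protein 1 (Mus musculus) (a lower number here means a stronger inhibitor, a higher number a weaker inhibitor), so its value is "not determined" (no result reported). Compound 2 gives only a limit in this assay, namely > 10000 nM, which means no number could be read off within the tested range. So compound 2 stands at the limit of > 10000 nM in this assay, at which 1 of the 2 values shown sits, and nothing more exact is known about it.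

Compound 3, `CCn1nnc(-c2ccc(NC(=O)CSc3nnc(CNc4ccccc4)n3CC)cc2)n1`, is not yet measured. It differs from compound 2 by 2-ethyl-2H-tetrazol-5-yl in place of methylcarbamoyl on an aromatic carbon. Going by the values given here, with no measured step in this set to lean on, the size of the change from compound 2 to compound 3 in this assay cannot be read from the data; the only anchor is the limit of compound 2. The step is expected to be an at least 1.2-fold lower number from compound 2 to compound 3 (0.09 log units; that floor lies within the scatter). Compound 3 is therefore estimated at 8000 nM, within a range from 2000 nM to 30000 nM, with a real chance that again only a limit is reported.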

Compound 3, half-maximal inhibitory concentration: > 10000 nM
Compound 3 gave a limit, no number; the forecaster's own chance of this, stated with the estimate: 55%; middle value at least 1.2-fold (0.09 log units) from the limit.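

Compound 2 and compound 3 each give only a limit in this assay, so no step between them can be read: the limit of > 10000 nM in this assay, at which 2 of the 3 values shown sit.

The compounds shown leave open how strongly either one inhibits, and whether 2-ethyl-2H-tetrazol-5-yl in place of methylcarbamoyl changes inhibition at all.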